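The source may hold more compounds than are shown below. What is called first, only, known or untested is meant among the compounds shown, and "the series" means these compounds.

Measured compounds in a functional assay on MDA-MB-231 cells (Homo sapiens) for cytotoxicity, read by sulforhodamine B assay, with a stated time of 48 h; a higher number here means that more compound is tolerated, a lower number that less compound is tolerated:
compound 1, `ClCc1ccc(Cn2cnc3c(Cl)ncnc32)cc1`, gives 8700 nM;
compound 2, `Nc1nc(Cl)c2ncn(Cc3ccc(CCl)cc3)c2n1`, gives 91200 nM;
compound 3, `ClCc1ccccc1Cn1cnc2c(Cl)ncnc21`, gives 45700 nM.

Compound 1 and compound 2 share a core and differ in one place: amino in place of hydrogen on an aromatic carbon. In this assay this change made a large step, a 10-fold higher number from compound 1 to compound 2 (1.02 log units; beyond the scatter). Compound 3 carries the same atoms as compound 1 joined differently; the difference between the two cores is not broken down here. The value of compound 3 lies within the usual scatter of that of compound 2, while compound 1 gives a lower number than compound 3.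

Compound 4, `Nc1nc(Cl)c2ncn(Cc3ccccc3CCl)c2n1`, has not been measured. It differs from compound 3 in one place: amino in place of hydrogen on an aromatic carbon. This is the same change that was made from compound 1 to compound 2, and the surroundings of the place are described in the same words. Among the measured compounds shown here, for compound 4 the step expected in this assay is a 6.6-fold higher number from compound 3 to compound 4 (0.82 log units; beyond the scatter) because a 10-fold higher number from compound 1 to compound 2 (1.02 log units; beyond the scatter) is the only measurement of this change. On this basis compound 4 is estimated at 300000 nM, between 100000 nM and 900000 nM.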

Compound 4, concentration lethal to 50% of the cells: 63100 nM
Compound 4: middle estimate off by 4.8-fold (0.68 log units), on the high side, outside the stated range (below it).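

In this assay, amino in place of hydrogen on an aromatic carbon gave a step that stays within the usual scatter (a 1.4-fold higher number from compound 3 to compound 4 (0.14 log units; within the scatter)), so on the core of compound 3 this change has no effect that can be told from repeat measurement. Set beside the earlier pair, the two steps differ, and the size of the step did not carry over from one core to the other: the same change on two cores in this assay, a 10-fold higher number (1.02 log units; beyond the scatter) from compound 1 to compound 2 and a 1.4-fold higher number (0.14 log units; within the scatter) from compound 3 to compound 4, 7.6-fold (0.88 log units) apart, beyond the scatter of two such steps. This shows that in these two pairs the outcome of the change was tied to the core that carried it, but two pairs do not show which difference between the cores accounts for the gap, nor how the change would behave on any further core.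

The compounds shown leave open whether a methyl or a methoxy group in the same place would also give steps that differ between the two cores. They also leave open whether a bromomethyl group in place of the chloromethyl group would alter the picture.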